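The source may hold more compounds than are shown below. What is called first, only, known or untested is meant among the compounds shown, and "the series" means these compounds.

Working notes on the series. In an ADME assay on HEK293 cells (Homo sapiens) for cytotoxicity, read by fluorescence and resazurin assay, with a stated time of 24 h (a lower number here means that less compound is tolerated, a higher number that more compound is tolerated), compound 1 (`O=S1(=O)C=C(Sc2nnc(-c3cccnc3)o2)c2ccccc21`) gives 4000 nM and compound 2 (`Nc1ccc(-c2nnc(SC3=CS(=O)(=O)c4ccccc43)o2)cc1`) gives 4000 nM. Compound 3 (`Cc1ccc(-c2nnc(SC3=CS(=O)(=O)c4ccccc43)o2)cc1`) gives 3000 nM and stands level with both, its gaps to each lying within the scatter.

Next comes compound 4 (`O=S1(=O)C=C(Sc2nnc(-c3cccc(Cl)c3)o2)c2ccccc21`), not yet measured, which carries 3-chlorophenyl in place of 4-methylphenyl on an aromatic carbon of the five-membered aromatic ring (3-chlorophenyl in place of 4-methylphenyl on an aromatic carbon). Among the measured compounds shown here, three measured steps bear on this change, all made in the same group. Exchanging pyridin-3-yl for 4-aminophenyl gave no change (no change at the digits printed from compound 1 to compound 2 (within the scatter)). Exchanging pyridin-3-yl for 4-methylphenyl stayed within the scatter (a 1.3-fold lower number from compound 1 to compound 3 (0.12 log units; within the scatter)), as did methyl in place of amino (a 1.3-fold lower number from compound 2 to compound 3 (0.12 log units; within the scatter)). None of the three measured compounds carries chlorine, so the flat picture rests on these three alone and gives only a loose guide for the new group.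

In this assay no step beyond the scatter is expected and no direction is favoured (no change at the digits printed from compound 3 to compound 4 (within the scatter)) on the strength of those three steps. Compound 4 is estimated at 3000 nM with an expected range from 1300 nM to 6000 nM for the half-maximal cytotoxic concentration.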

Compound 4, half-maximal cytotoxic concentration: 6000 nM
The estimate for compound 4 lay 2.0-fold (0.30 log units) below the measured number, and the stated range covers the measured number.
By their numbers in this assay, from the lowest: compounds 3, 1, 2 and 4 (each within the scatter of the next).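

The position on the five-membered aromatic ring with 2 nitrogen and 1 oxygen also accepts a chlorine-bearing aryl group: in this assay, 3-chlorophenyl stays within the scatter of all three earlier groups (a 2.0-fold higher number from compound 3 to compound 4 (0.30 log units; within the scatter); a 1.5-fold higher number from compound 2 to compound 4 (0.18 log units; within the scatter); a 1.5-fold higher number from compound 1 to compound 4 (0.18 log units; within the scatter)). The flat picture among the pyridin-3-yl, 4-aminophenyl and 4-methylphenyl compounds therefore extends to a fourth aryl group, and compounds 1 to 4 now span a halogen, an amino group, a methyl group and a ring nitrogen with no step beyond the scatter. No measurement available here bears on why this position tolerates these exchanges, so the result stands as an observation only.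

All four groups are six-membered aromatic rings of similar size, so the compounds shown leave open whether the flat picture holds for a carboxylic acid on the phenyl ring, a morpholine ring or a longer alkyl chain at this position. They also leave open whether the shared core contributes to the cytotoxicity read here, since every compound carries it unchanged and the groups tested at this one position are the only variation.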